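The source may report more compounds than this note shows. Statements on the series, on what has been measured and on what is new or still open speak of the compounds shown alone.

Of the compounds shown here, three sharing one core have been measured in a functional assay on OVCAR-3 cells (Homo sapiens) for cytotoxicity, read by sulforhodamine B assay; a higher number here means a weaker inhibitor of growth, a lower number a stronger inhibitor of growth. Compound 1 `CC1=CC[C@@H]([C@@](C)(O)CCCC(C)(C)NC(=S)N/N=C\c2ccccc2)CC1` gives 6970 nM. Compound 2 `COc1ccc(/C=N\NC(=S)NC(C)(C)CCC[C@](C)(O)[C@@H]2CC=C(C)CC2)cc1` gives 6500 nM in this assay. Compound 3 `CC1=CC[C@@H]([C@@](C)(O)CCCC(C)(C)NC(=S)N/N=C\c2ccc(O)cc2)CC1` gives 6230 nM in this assay. Compound 3 holds the lowest of the three numbers, but its gaps to the other two are within the scatter: a 1.1-fold lower number from compound 1 to compound 3 (0.05 log units; within the scatter) and a 1.0-fold lower number from compound 2 to compound 3 (0.02 log units; within the scatter). The remaining step is of the same kind: a 1.1-fold lower number from compound 1 to compound 2 (0.03 log units; within the scatter). Compound 4 `CC1=CC[C@@H]([C@@](C)(O)CCCC(C)(C)NC(=S)N/N=C\c2ccc(N(C)C)cc2)CC1` has not yet been measured. It differs from compound 3 in one place: dimethylamino in place of hydroxy on an aromatic carbon. All three measured steps exchange the group on this aromatic carbon, and none of them moved this assay beyond the scatter. Exchanging hydroxy for dimethylamino is expected to behave in the same way, giving no step beyond the scatter in this assay from compound 3 to compound 4. The estimated step is a 1.0-fold lower number from compound 3 to compound 4 (0.02 log units; within the scatter). Compound 4 is estimated at 6000 nM, with a range from 2500 nM to 14000 nM.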

Compound 4, concentration for 50% growth inhibition: 3600 nM
Beside the measured number, compound 4's estimate is 1.7-fold (0.22 log units) above it; measured number inside the range.
By their numbers in this assay, from the lowest: compounds 4, 3, 2 and 1 (each within the scatter of the next).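

In this assay, exchanging hydroxy for dimethylamino on this aromatic carbon gives a 1.7-fold lower number from compound 3 to compound 4 (0.24 log units; within the scatter), so a group of three heavy atoms with no hydrogen-bond donor still leaves the number within the scatter. The comparisons with methoxy and with plain hydrogen read the same way, with a 1.8-fold lower number from compound 2 to compound 4 (0.26 log units; within the scatter) and a 1.9-fold lower number from compound 1 to compound 4 (0.29 log units; within the scatter), so all four groups at this position remain indistinguishable in this assay. Nothing measured here offers an explanation for this result.

As far as these compounds go, whether any group on this carbon can move the number beyond the scatter stays open, for example a carboxylic acid or a nitro group. Also open, from the compounds shown here alone, is how the number would respond to a change elsewhere, such as a longer chain on the shared core.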